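Swapping a Butyl Tail for a Halogenated Methoxy Group

This account rests on a few compounds, and the source may have more. Where it says the series, first, only, none or still open, it means among the compounds named here.

Of the compounds shown here, three built on one shared core have been tested in an assay on mitochondria from L6 cells (Rattus norvegicus) for activation, with a stated time of 90 min; on this read-out higher numbers stand for an effect only at larger amounts of compound and lower numbers for an effect already at smaller amounts. Compound 1 `CCCCOc1ccc(Nc2nc3nonc3nc2O)cc1` gives 3700 nM. Compound 2 `CCCCc1ccc(Nc2nc3nonc3nc2O)cc1` gives 2100 nM, and compound 3 `CCCCc1ccc(Nc2nc3nonc3nc2O)c(F)c1` gives 1100 nM. Compound 2 stands second highest of the three numbers; its nearest neighbour is compound 1 and its furthest is compound 3, and both of those gaps remain within the usual scatter. Putting butyl in place of butoxy brought a 1.8-fold lower number from compound 1 to compound 2 (0.25 log units; within the scatter), and putting fluoro in place of hydrogen brought a 1.9-fold lower number from compound 2 to compound 3 (0.28 log units; within the scatter).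

Compound 4 `Oc1nc2nonc2nc1Nc1ccc(OC(F)(F)Cl)cc1` has not yet been measured. It differs from compound 2 in one place: chloro(difluoro)methoxy in place of butyl on an aromatic carbon. Going by the values given here, the measured step that bears most on this change is the one from compound 1 to compound 2, where a chain attached through oxygen was exchanged for a chain attached through carbon and the number moved only within the scatter. Compound 4 brings back a group attached through oxygen, now carrying a single carbon that bears halogens instead of a four-carbon chain. Among the compounds with values here, with that step as the only guide, the number for compound 4 is expected to stay close to that of compound 2 in this assay, and compound 4 is estimated at 2500 nM, within a range from 1000 nM to 6500 nM. That estimate amounts to an expected 1.2-fold higher number from compound 2 to compound 4 (0.08 log units; within the scatter).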

Compound 4, half-maximal effective concentration: 1900 nM
Beside the measured number, compound 4's estimate is 1.3-fold (0.12 log units) above it; the range from low to high includes it.
By their numbers in this assay, from the lowest: compounds 3, 4, 2 and 1 (each within the scatter of the next, the first and the last beyond it).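

At this place, on an aromatic carbon para to a large group, butyl and chloro(difluoro)methoxy cannot be told apart in this assay: the exchange gives a 1.1-fold lower number from compound 2 to compound 4 (0.04 log units; within the scatter), even though the two groups share neither their atoms nor their shape, and only the entering group counts a hydrogen-bond acceptor. Keeping the oxygen and changing only what sits on it, with chloro(difluoro)methyl in place of butyl, gives a 1.9-fold lower number from compound 1 to compound 4 (0.29 log units; within the scatter), so a group carrying halogens on a single carbon also stays within the scatter of the four-carbon chain it replaces on that oxygen. No other measurement is available that bears on what lies behind these numbers.

Every exchange at this place shown so far stays within the scatter, so it remains open whether any group here can move the number beyond it, for example an amine, a carboxylic acid or a chain longer than butyl. Also open, on these data alone, is whether fluoro on the ring, as carried by compound 3 alongside butyl, would give a similar step when paired with chloro(difluoro)methoxy.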